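Moving the hydroxyl on one aryl arm of a pyridine-type core

The source may hold more compounds than are shown below. What is called first, only, known or untested is meant among the compounds shown, and "the series" means these compounds.

Compound 1: `Oc1cccc(-c2cc(-c3ccsc3)cc(-c3cccc(O)c3)n2)c1` — 1310 nM
Compound 2: `Oc1cccc(-c2cc(-c3ccco3)cc(-c3cccc(O)c3)n2)c1` — 2150 nM
Compound 3: `Oc1cccc(-c2cc(-c3ccoc3)cc(-c3ccccc3O)n2)c1` — 2790 nM

All three compounds were tested in a functional assay on DU-145 cells (Homo sapiens) for cytotoxicity, read by CCK-8 assay; a lower number here means a stronger inhibitor, a higher number a weaker inhibitor. Compound 3 has the highest number of the three; its gap to compound 2 lies within the scatter, while its gap to compound 1 lies beyond it, so compound 3 is at the weaker end of this small set without being clearly separated from compound 2.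

Compound 4, `Oc1cccc(-c2cc(-c3ccoc3)cc(-c3cccc(O)c3)n2)c1`, differs from compound 3 in one place: 3-hydroxyphenyl in place of 2-hydroxyphenyl on an aromatic carbon. The change sits on an aromatic carbon of a six-membered aromatic ring with one nitrogen, next to the ring nitrogen, meta to a 3-hydroxyphenyl group and meta to a furan-3-yl group.

Within the data shown here, no measured step moves the hydroxyl from one position to another on this arm. Among the measured compounds shown here, the only step available, a 1.6-fold higher number from compound 1 to compound 2 (0.22 log units; within the scatter), swaps the five-membered ring at a different position and stays within the scatter, so it offers no direct guidance here. What can be said is that compounds 1 and 2, which both carry two 3-hydroxyphenyl arms, give numbers near and somewhat below compound 3. Compound 4 is therefore expected to show at most a modest shift, a 1.4-fold lower number from compound 3 to compound 4 (0.14 log units; within the scatter), with the estimate for compound 4 placed at 2000 nM and a range from 900 nM to 4500 nM.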

Compound 4, half-maximal inhibitory concentration: 1650 nM
The estimate for compound 4 lay 1.2-fold (0.08 log units) above the measured number; measured number inside the range.
By their numbers in this assay, from the lowest: compounds 1, 4, 2 and 3 (each within the scatter of the next, the first and the last beyond it).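

In this assay, among these compounds, swapping 2-hydroxyphenyl for 3-hydroxyphenyl gives the first direct comparison of the two arms at this place on the core, and the result is a 1.7-fold lower number from compound 3 to compound 4 (0.23 log units; within the scatter), so moving the hydroxyl around this arm produces no difference that can be told apart from ordinary repeat variation. Compound 4 also allows two comparisons of the five-membered ring with both arms as 3-hydroxyphenyl: a 1.3-fold lower number from compound 2 to compound 4 (0.11 log units; within the scatter) for furan-3-yl in place of furan-2-yl, and a 1.3-fold higher number from compound 1 to compound 4 (0.10 log units; within the scatter) for furan-3-yl in place of thiophen-3-yl, so neither swap separates these compounds either. No measured information on the origin of these small steps is available here.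

The compounds shown leave open whether a clearer difference would appear if the hydroxyl on this arm were replaced by an amine or a carboxylic acid, or if the arm carried 4-hydroxyphenyl. They also leave open whether 2-hydroxyphenyl and 3-hydroxyphenyl would remain this close with thiophen-3-yl or furan-2-yl on the core instead of furan-3-yl.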